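The compounds below may be only part of what the source reports. "The series", "measured", "known", "first", "only" and "open" are said of these compounds alone.

Working notes on the series built around the shared core of compound 2 `O=C(Nc1ccc2cccnc2c1)c1ccc(-c2ccc(Cl)cc2)nc1`. Among the compounds with values here, in an in vitro functional assay on 1321-N1 cells for antagonist activity at transient receptor potential cation channel subfamily V member 1 (Homo sapiens), read by FLIPR and calcium flux (a higher number here means a more potent compound, by a factor of ten per unit of this negative logarithm, a lower number a less potent compound), compound 2 gives 7.8, the only number so far recorded. Compound 1 `N#Cc1ccc(-c2ccc(C(=O)Nc3ccc4cccnc4c3)cn2)cc1` carries a cyano group where compound 2 carries chloro. For compound 1 this assay returns only a limit, < 6.6. Within the data shown here, the single measured step, a number at least 1.20 log units higher from compound 1 to compound 2 (beyond the scatter), is accordingly known only as a lower bound on its size, a consequence of the limit of < 6.6 in this assay, at which 1 of the 2 values shown sits.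

Compound 3 `O=C(Nc1ccc2cccnc2c1)c1ccc(-c2ccc(C(F)(F)F)cc2)nc1` is the next member to be run: trifluoromethyl in place of chloro on an aromatic carbon. Among the measured compounds shown here, no measured step in this set involves a trifluoromethyl group, and the one step in hand compares cyano with chloro, not chloro with trifluoromethyl, so it gives no direction for the present change. A step of a number 0.10 log units lower from compound 2 to compound 3 (within the scatter) in this assay is expected, not beyond the scatter. The estimate for compound 3 is 7.7, with a range from 7 to 8.4.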

Compound 3, negative logarithm of the antagonist equilibrium constant: 7.3
Compound 3: the middle estimate sits 0.40 log units above what was measured; the range from low to high includes it.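

Trifluoromethyl and chloro on this aromatic carbon, para to a large group, are not interchangeable in this assay, where the measured step is a number 0.50 log units lower from compound 2 to compound 3 (beyond the scatter) and the larger group gives the lower number. Trifluoromethyl still stands apart from cyano at the same place, with a number at least 0.70 log units higher from compound 1 to compound 3 (beyond the scatter) as the step, so the three compounds now place chloro, trifluoromethyl and cyano in that descending order, each step beyond the scatter. Both steps from the cyano compound can be read only as lower bounds, because compound 1 has a limit and not a number: the limit of < 6.6 in this assay, at which 1 of the 3 values shown sits.

The compounds shown leave open how an amine, a carboxylic acid or a methoxy group on this aromatic carbon would read in this assay, as all three substituents here carry no hydrogen-bond donors and no net charge in the two groups compared. Also open, going by these compounds, is whether the order among chloro, trifluoromethyl and cyano would hold on any core other than the shared one.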